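The source may report more compounds than this note shows. Statements on the series, on what has been measured and on what is new or still open speak of the compounds shown alone.

Three compounds of one shared core were tested in an assay on isolated protein for inhibition of 2-Hydroxyacid oxidase 2 (Homo sapiens), tested at 1 uM; a lower number here means a weaker effect, a higher number a stronger effect of the compound at the concentration tested. Compound 1 `Cc1n[nH]c(C(=O)O)c1Cc1ccc(C(F)(F)F)cc1` gives 9% in this assay. Compound 2 `Cc1n[nH]c(C(=O)O)c1Cc1ccccc1C(F)(F)F` gives 13%, and compound 3 `Cc1n[nH]c(C(=O)O)c1Cc1cccc(C#N)c1` gives 6%. All three numbers lie within the usual scatter of one another, so compound 1 stands among them without separation from either neighbour. Compound 4 `Cc1n[nH]c(C(=O)O)c1Cc1ccc(C#N)cc1` has not yet been measured in this assay. It differs from compound 1 in one place: cyano in place of trifluoromethyl on an aromatic carbon. Within the data shown here, no measured pair shows this kind of step, so its size cannot be read from the data. Compound 3 also carries cyano and gives 6%, which points to a small step. The expected step in this assay is a number 2 percentage points lower from compound 1 to compound 4 (within the scatter), none beyond the scatter. Compound 4 is therefore estimated at 7% in this assay, within a range of 0% to 18%.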

Compound 4, a percentage reported as inhibition, at one concentration (the size of the read-out at that concentration, not a potency): 0%
The estimate for compound 4 lay 7 percentage points above the measured number, and the stated range covers the measured number.
By their numbers in this assay, from the lowest: compounds 4, 3, 1 and 2 (each within the scatter of the next, the first and the last beyond it).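

At the aromatic carbon para to a large group, the exchange of trifluoromethyl for cyano can now be read directly in this assay: a number 9 percentage points lower from compound 1 to compound 4 (within the scatter). At this position, therefore, the change does not separate the two compounds, even though cyano has fewer heavy atoms and adds a hydrogen-bond acceptor. No measurement available here bears on the reason for this result. The compounds shown leave open whether an amine or a carboxylic acid at this position would move the read-out in this assay beyond the scatter from compound 1.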